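The compounds below may be only part of what the source reports. "The series", "measured", "known", "first", "only" and "open" are said of these compounds alone.

In an ADME assay on BJ cells (Homo sapiens) for antiproliferative activity, with a stated time of 72 h (a lower number here means that less compound is needed, a higher number that more compound is needed for the effect), compound 1 `COc1ccc(-c2cc(=O)c3c(OC)cc(OC)cc3[nH]2)cc1` gives only a limit, > 62000 nM. Compound 2 `COc1ccc(-c2cc(=O)c3c(OC)cc(OC)cc3n2Cc2ccccc2)cc1`, which carries a benzyl on the aromatic nitrogen of the shared core, likewise gives only a limit in this assay, > 34400 nM. Compound 3 `COc1ccc(-c2cc(=O)c3c(OC)cc(OC)cc3n2S(=O)(=O)c2ccc(C=O)cc2)cc1`, with a (4-formylphenyl)sulfonyl on that nitrogen, also reaches only a limit in this assay, > 34400 nM. Compound 3 therefore stands at the limit of > 34400 nM in this assay, at which 2 of the 3 values shown sit. Compound 1 sits at the limit of > 62000 nM in this assay, at which 1 of the 3 values shown sits. All three steps between the measured compounds are unreadable: a step that the two limits leave unreadable from compound 1 to compound 2, a step that the two limits leave unreadable from compound 1 to compound 3 and a step that the two limits leave unreadable from compound 2 to compound 3.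

Compound 4 `COc1ccc(-c2cc(=O)c3c(OC)cc(OC)cc3n2S(=O)(=O)c2ccc([N+](=O)[O-])cc2)cc1` differs from compound 3 by nitro in place of formyl on an aromatic carbon. Among the compounds with values here, no measured step offers a readable size or direction to build on, so the expectation rests on the three limits alone, and the step that the limit leaves unreadable from compound 3 to compound 4 is expected to be no larger than the scatter. Compound 4 is expected to give about 60000 nM in this assay, with a range from 15000 nM to 250000 nM, most likely again as a limit.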

Compound 4, half-maximal effective concentration: > 29300 nM
Compound 4: a limit, no number; the forecaster's own chance of this, stated with the estimate: 80%; the middle value is on the limit's open side.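

In this assay compound 3 and compound 4 both give only limits, not numbers, so the step from formyl to nitro cannot be read. The compounds shown leave open whether any of them reaches a measurable half-maximal effect in this assay, and at what concentration.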